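Benzyl in place of aryl on the ring nitrogen

The source may hold more compounds than are shown below. What is called first, only, known or untested is meant among the compounds shown, and "the series" means these compounds.

Compound 1 `CCCn1c(=O)[nH]c2nc(-c3ccc(S(=O)(=O)N4CCN(c5cccc(Cl)c5)CC4)cc3)[nH]c2c1=O` is the reference point of this note. For the measured compounds named here, in an assay on CHO cells for displacement of a labelled ligand from adenosine receptor A3 (Homo sapiens), read by scintillation counting, with a stated time of 45 min, in the presence of a further agent that is not named here (a higher number here means a weaker inhibitor, a lower number a stronger inhibitor), compound 1 gives 53.5 nM, the only number available for the series. Compound 2 `CCCn1c(=O)[nH]c2nc(-c3ccc(S(=O)(=O)N4CCN(c5ccccc5)C(C)C4)cc3)[nH]c2c1=O` is reported in this assay only as a limit of the assay, > 1000 nM. That point is recorded as the limit of > 1000 nM in this assay, at which 1 of the 2 values shown sits, and shows how readily a change around the ring nitrogen can push a member of the series past what the assay still resolves. Going by the values given here, no step between two measured compounds is recorded, so no measured step covers a change of the kind now considered.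

Compound 3 `CCCn1c(=O)[nH]c2nc(-c3ccc(S(=O)(=O)N4CCN(Cc5ccc(Br)cc5)CC4)cc3)[nH]c2c1=O` differs from compound 1 by 4-bromobenzyl in place of 3-chlorophenyl on an amine nitrogen in a ring. Among the compounds with values here, with no measured step of this kind to lean on, the expectation for this assay is a weakening that goes beyond the usual scatter, though less severe than falling to a limit. Compound 3 is therefore estimated at 250 nM, with a plausible range from 60 nM to 1200 nM. The expected step is a 4.7-fold higher number from compound 1 to compound 3 (0.67 log units; beyond the scatter).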

Compound 3, inhibition constant: > 1000 nM
Compound 3: only a limit was reported; the forecaster's own chance of this, stated with the estimate: 25%; middle value at least 4.0-fold (0.60 log units) away from the limit.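

In this assay, for the compounds shown here, 4-bromobenzyl in place of 3-chlorophenyl on an amine nitrogen in a ring gives an at least 18-fold higher number from compound 1 to compound 3 (1.27 log units; beyond the scatter), the only measured step so far, and it shows that this ring nitrogen does not accept every aromatic substituent without a large loss of binding. On these data alone, compound 3 is recorded only as a limit of the assay, so this step sets a lower bound on the loss, and its true size remains unknown. Compound 1 therefore remains the only compound with a number, and the readout at this position is now dominated by the limit: the limit of > 1000 nM in this assay, at which 2 of the 3 values shown sit.

The step changes several things at once, as a carbon enters between the ring nitrogen and the aromatic ring while bromine at the 4-position replaces chlorine at the 3-position, so the data cannot assign the loss to any one of these changes. As far as these compounds go, a 3-chlorobenzyl group would isolate the added carbon and a 4-bromophenyl group would isolate the halogen change, while the behaviour of an unsubstituted benzyl or a pyridyl ring at this nitrogen remains open.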